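The source may report more compounds than this note shows. Statements on the series, on what has been measured and on what is new or still open speak of the compounds shown alone.

In a functional assay on Vero cells (Chlorocebus sabaeus) for inhibition (a higher number here means a weaker inhibitor, a lower number a stronger inhibitor), three compounds sharing one core have been measured. Compound 1 `COc1cc(/C=C/C(=O)c2cccc(NC(=O)c3cccs3)c2)ccc1O` gives 3.98 ug/mL and compound 2 `COc1cc(/C=C/C(=O)c2cccc(N)c2)ccc1O` gives 6.02 ug/mL, and a 1.5-fold higher number from compound 1 to compound 2 (0.18 log units; within the scatter) stays within the scatter. Compound 3 `COc1cc(/C=C/C(=O)c2cccc(NC(=O)c3ccc(Cl)c(Cl)c3)c2)ccc1O` reads > 50 ug/mL, which is a limit of the assay and not a number.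

Compound 4 `COc1cc(/C=C/C(=O)c2cccc(NC(=O)C(C)C)c2)ccc1O` carries one change from compound 3: isopropyl in place of 3,4-dichlorophenyl on a carbonyl carbon, with isopropyl in place of 3,4-dichlorophenyl on a carbonyl carbon. Within the data shown here, two measured steps bear on this, an at least 12-fold higher number from compound 1 to compound 3 (1.09 log units; beyond the scatter) and an at least 8.3-fold higher number from compound 2 to compound 3 (0.91 log units; beyond the scatter), both beyond the scatter and both leading to the 3,4-dichlorophenyl group. Taking that group away should therefore reverse them, giving a sizeable drop in this assay. The expected change is an at least 6.2-fold lower number from compound 3 to compound 4 (0.79 log units; beyond the scatter). For compound 4 the estimated value is 8 ug/mL, with an expected range of 3 ug/mL to 30 ug/mL.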

Compound 4, half-maximal inhibitory concentration: 3.47 ug/mL
For compound 4 the middle estimate is 2.3-fold (0.36 log units) above the measured one; low and high end bracket the measured number.
By their numbers in this assay, from the lowest: compounds 4, 1 and 2 (each within the scatter of the next). At a limit, above all of these: compound 3.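

In this assay, the group on this carbonyl carbon need not be a ring: with isopropyl in that place, the steps are a 1.1-fold lower number from compound 1 to compound 4 (0.06 log units; within the scatter) and a 1.7-fold lower number from compound 2 to compound 4 (0.24 log units; within the scatter). The loss with 3,4-dichlorophenyl therefore does not extend to every group here, nor to every amide on this nitrogen, and the step back is an at least 14-fold lower number from compound 3 to compound 4 (1.15 log units; beyond the scatter). The reading of compound 3 behind that step is a limit of the assay and not a number: the limit of > 50 ug/mL in this assay, at which 1 of the 4 values shown sits.

A plain phenyl or a 4-chlorophenyl group on this carbonyl carbon would show whether the loss follows the chlorine atoms or the ring. A longer chain ending in an amine would show how far the isopropyl result extends.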